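Anilino thiazolidinedione series: removal of the benzyl tert-butyl

The source may report more compounds than this note shows. Statements on the series, on what has been measured and on what is new or still open speak of the compounds shown alone.

Three compounds carry numbers in a functional assay on FM3A cells (Mus musculus) for cytotoxicity, read by cell counting, with a stated time of 2 days; a lower number here means a stronger inhibitor, a higher number a weaker inhibitor. Compound 1 `C=C(Br)C(=O)Nc1cccc(/C=C2\SC(=O)N(Cc3ccc(Cl)cc3)C2=O)c1` gives 1600 nM. Compound 3 `C=C(Br)C(=O)Nc1ccc(/C=C2\SC(=O)N(C)C2=O)cc1` gives 750 nM. Compound 2 `CC(C)(C)c1ccc(CN2C(=O)S/C(=C\c3cccc(N)c3)C2=O)cc1` gives 188000 nM, the highest of the three numbers; compound 1 is its nearest neighbour, well below it, and compound 3 lies lower still, both gaps beyond the scatter. Among the measured compounds shown here, compounds 1 and 3 carry a bromoacrylamide that compound 2 lacks, compound 2 carrying a primary amine in its place; nothing among the measured compounds separates the effect of that amine from the effect of the tert-butyl.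

Compound 4 `Nc1cccc(/C=C2\SC(=O)N(Cc3ccccc3)C2=O)c1` keeps the primary amine and differs from compound 2 in one place: hydrogen in place of tert-butyl on an aromatic carbon. For the measured compounds named here, no measured pair shows this change, so its size is not known from the data. Because compound 2 already stands at 188000 nM and the change removes only the tert-butyl, compound 4 is expected to remain near the same level, the estimated step of a 1.3-fold lower number from compound 2 to compound 4 (0.10 log units; within the scatter) lying within the scatter. Compound 4 is estimated at 150000 nM, within 40000 nM to 450000 nM.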

Compound 4, half-maximal inhibitory concentration: > 250000 nM
Compound 4: a limit, no number (the forecaster's own chance of this, stated with the estimate: 20%); at least 1.6-fold (0.22 log units) between middle value and limit.
By their numbers in this assay, from the lowest: compound 3; then compound 1; then compound 2. At a limit, above all of these: compound 4.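

In this assay compound 4 gives > 250000 nM, which is a limit of the assay and not a number. Hydrogen in place of tert-butyl on the aromatic carbon gives an at least 1.3-fold higher number from compound 2 to compound 4 (0.12 log units; that floor lies within the scatter), so at this position, with the primary amine kept, taking away the tert-butyl brings no drop in the number. The step has only a floor and no upper size because the reading of compound 4 ends at the limit: the limit of > 250000 nM in this assay, at which 1 of the 4 values shown sits.

Still open, from the compounds shown here alone, is whether a methyl or a methoxy group at this same position would move the number in either direction. Also open is what a bromoacrylamide in place of the primary amine would do on the core of compound 4, since no pair shown changes that group alone.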